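The source may report more compounds than this note shows. Statements on the series, on what has been measured and on what is new or still open speak of the compounds shown alone.

Three compounds of this series share one core and differ only in the bicyclic aromatic part carrying the amide. Compound 1 `CSc1cc(C)[nH]c(=O)c1CNC(=O)c1c(C)n([C@H](C)[C@H]2CC[C@H](N3CC(OC4CC4)C3)CC2)c2ccccc12` gives 3.5 nM in an assay on HeLa cells for inhibition of histone-lysine N-methyltransferase EZH2 (Homo sapiens), read by AlphaLISA, with a stated time of 72 h; a higher number here means that more compound is needed for the effect, a lower number that less compound is needed. Compound 2 `CSc1cc(C)[nH]c(=O)c1CNC(=O)c1c(C)n([C@H](C)[C@H]2CC[C@H](N3CC(OC4CC4)C3)CC2)c2ncccc12` gives 1.8 nM in this assay, and compound 3 `CSc1cc(C)[nH]c(=O)c1CNC(=O)c1c(C)n([C@H](C)[C@H]2CC[C@H](N3CC(OC4CC4)C3)CC2)c2ncncc12` gives 6.3 nM. The number for compound 2 is the lowest of the three; against compound 1 the gap lies within the scatter, so no order between those two can be read, while against compound 3 the gap lies beyond the scatter.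

Compound 4 `CSc1cc(C)[nH]c(=O)c1CNC(=O)c1c(C)n([C@H](C)[C@H]2CC[C@H](N3CC(OC4CC4)C3)CC2)c2ncc(Cl)cc12` follows from compound 2 by chloro in place of hydrogen on an aromatic carbon. Within the data shown here, no measured pair carries this change, so its effect cannot be read from the data. The expectation for the step from compound 2 to compound 4 is a 1.4-fold higher number from compound 2 to compound 4 (0.14 log units; within the scatter), no shift beyond the scatter in either direction. Compound 4 is therefore estimated at 2.5 nM in this assay, with a range from 1 nM to 7 nM.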

Compound 4, half-maximal effective concentration: 3.5 nM
The estimate for compound 4 lay 1.4-fold (0.15 log units) below the measured number, and the stated range covers the measured number.
By their numbers in this assay, from the lowest: compounds 2, 1, 4 and 3 (each within the scatter of the next, the first and the last beyond it).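

Compounds 1 to 3 differ only in the ring atoms of the bicyclic part, so compound 4 is the first of those shown to carry a substituent on this aromatic carbon, two atoms from the ring nitrogen. In this assay, chloro in place of hydrogen gives a 1.9-fold higher number from compound 2 to compound 4 (0.29 log units; within the scatter), so this one added chlorine atom produces no shift beyond the scatter at this position. No measurement shown accounts for this result.

This single step leaves open whether other groups on the same carbon, such as fluoro, methoxy, nitrile or an amine, would also stay within the scatter. It also leaves open whether chloro would give a similar step on the shared core with the ring atoms of compound 1 or compound 3.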